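Sulfonamide Nitrogen Aryl Swap on a Shared Core

The source may hold more compounds than are shown below. What is called first, only, known or untested is meant among the compounds shown, and "the series" means these compounds.

Compound 1 `CCc1ccccc1N(CC(=O)NCc1ccc(C(F)(F)F)cc1)S(=O)(=O)c1ccc(C)cc1` is measured in a functional assay on CHO-K1 cells for antagonist activity at prostaglandin E2 receptor EP1 subtype (Homo sapiens), read by FLIPR and calcium flux (on this read-out higher numbers stand for weaker inhibition and lower numbers for stronger inhibition), and gives 209 nM. Compound 2 `Cc1ccc(S(=O)(=O)N(CC(=O)NCc2ccc(Cl)cc2)c2cccnc2)cc1` in this assay gives only a limit of < 1450 nM, so it stands at the limit of < 1450 nM in this assay, at which 1 of the 2 values shown sits, and no exact number is known for it. Compound 3 `Cc1ccc(S(=O)(=O)N(CC(=O)NCc2ccc(Cl)cc2)c2cccc(C)n2)cc1` differs from compound 2 in one place: 6-methylpyridin-2-yl in place of pyridin-3-yl on a sulfonamide nitrogen. Going by the values given here, no measured step of this kind is available, so the direction is uncertain. The step from compound 2 to compound 3 is estimated as a step that the limit leaves unreadable from compound 2 to compound 3, a change expected to stay roughly within the scatter. Compound 3 is expected to reach about 400 nM, with a likely range from 80 nM to 2000 nM.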

Compound 3, inhibition constant: < 1450 nM
Compound 3: no number, only a limit; the forecaster's own chance of this, stated with the estimate: 30%; the middle value lies beyond the limit too.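

Compound 2 and compound 3 both give only a limit, not a number, so no step between them can be read: the limit of < 1450 nM in this assay, at which 2 of the 3 values shown sit.

Which of pyridin-3-yl and 6-methylpyridin-2-yl on the sulfonamide nitrogen gives stronger inhibition stays open.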